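Moving the amide substituent from methoxy to difluoro

The source may hold more compounds than are shown below. What is called first, only, known or untested is meant among the compounds shown, and "the series" means these compounds.

Measured so far:
Compound 1 `COc1ccccc1C(=O)Nc1cccc(-c2oc3cc(-c4ccc(F)cc4)ccc3c(=O)c2O)c1` gives 11700 nM in a functional assay on A549 cells (Homo sapiens) for antiproliferative activity, read by CCK-8 assay, with a stated time of 72 h; a higher number here means a weaker inhibitor, a lower number a stronger inhibitor.
Compound 2 `COc1ccc(C(=O)Nc2cccc(-c3oc4cc(-c5ccc(F)cc5)ccc4c(=O)c3O)c2)c(F)c1` gives 40000 nM in this assay.

Going by the values given here, compound 2 has the higher of the two numbers, and its only neighbour is compound 1, with a 3.4-fold higher number from compound 1 to compound 2 (0.53 log units; beyond the scatter).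

Compound 3 `O=C(Nc1cccc(-c2oc3cc(-c4ccc(F)cc4)ccc3c(=O)c2O)c1)c1cc(F)cc(F)c1` has not been measured. It differs from compound 2 by 3,5-difluorophenyl in place of 2-fluoro-4-methoxyphenyl on a carbonyl carbon.

Among the compounds with values here, no measured step covers this change: the one known step swaps groups on the same carbonyl carbon, not this pair. Compound 3 is therefore expected near compound 2, with a 1.6-fold lower number from compound 2 to compound 3 (0.20 log units; within the scatter) as a guess, and an estimated value of 25000 nM, within 8000 nM to 80000 nM.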

Compound 3, half-maximal inhibitory concentration: 7620 nM
Estimate against measurement, compound 3: 3.3-fold (0.52 log units) above; the whole stated range lies above it.
By their numbers in this assay, from the lowest: compounds 3 and 1 (each within the scatter of the next); then compound 2.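

On this carbonyl carbon, the aryl group can change the result in this assay, since 3,5-difluorophenyl in place of 2-fluoro-4-methoxyphenyl gives a 5.2-fold lower number from compound 2 to compound 3 (0.72 log units; beyond the scatter). Replacing 2-methoxyphenyl with 3,5-difluorophenyl gives a 1.5-fold lower number from compound 1 to compound 3 (0.19 log units; within the scatter), so compound 1 and compound 3 cannot be ranked, and a methoxy group is not required to reach this level. No available measurement explains these differences.

Still open, as far as these compounds go, is how a plain phenyl ring, a pyridine or a carboxylic acid would behave at this place. The compounds shown also cannot separate the contributions of the fluorine and the methoxy group in compound 2.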